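Ester-tail variations in the tetramethyltetralin amide series

The compounds below may be only part of what the source reports. "The series", "measured", "known", "first", "only" and "open" are said of these compounds alone.

Measured so far in a functional assay on K562 cells (Homo sapiens) for inhibition, read by MTT assay, with a stated time of 48 h; on this read-out higher numbers stand for weaker inhibition and lower numbers for stronger inhibition:
- Compound 1, `CCCC(=O)OCCCCOC(=O)c1ccc(C(=O)Nc2ccc3c(c2)C(C)(C)CCC3(C)C)cc1`, gives 92600 nM.
- Compound 2, `CCCC(=O)OCCOC(=O)c1ccc(C(=O)Nc2ccc3c(c2)C(C)(C)CCC3(C)C)cc1`, gives 18600 nM.
- Compound 3, `C=C(c1ccc(C(=O)OCCCCOC(=O)c2ccc(C(=O)Nc3ccc4c(c3)C(C)(C)CCC4(C)C)cc2)cc1)c1cc2c(cc1C)C(C)(C)CCC2(C)C`, returns only a limit of the assay, > 1000000 nM.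

Among the compounds with values here, of the two numbers, compound 2 holds the lower one, and the distance to compound 1 is beyond the scatter: the single measured step is a 5.0-fold lower number from compound 1 to compound 2 (0.70 log units; beyond the scatter). The value for compound 3 is a limit and is not counted as a number here; (the limit of > 1000000 nM in this assay, at which 1 of the 3 values shown sits).

Compound 4, `CCCC(CCC)C(=O)OCCCOC(=O)c1ccc(C(=O)Nc2ccc3c(c2)C(C)(C)CCC3(C)C)cc1`, differs from compound 2 by (((1-propylbutyl)carbonyl)oxy)methyl in place of (propylcarbonyl)oxy on a saturated chain carbon, two bonds along the chain from an oxygen next to a carbonyl group. Within the data shown here, the only step that bears on it is a 5.0-fold lower number from compound 1 to compound 2 (0.70 log units; beyond the scatter), a modest change in which the shorter link between the two ester oxygens went with the lower number. Compound 4 partly reverses that shortening and at the same time carries the 1-propylbutyl group where compound 2 carries propyl. Among the measured compounds shown here, no measured pair tests the acyl enlargement on its own, so the expectation rests on the link length alone, read as an intermediate case between compound 1 and compound 2.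

Compound 4 is therefore expected to come in weaker than compound 2, at an estimated 45000 nM with a range of 15000 nM to 180000 nM. The estimated step is a 2.4-fold higher number from compound 2 to compound 4 (0.38 log units; beyond the scatter).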

Compound 4, half-maximal inhibitory concentration: > 1000000 nM
Compound 4 gave a limit, no number (the forecaster's own chance of this, stated with the estimate: 5%); middle value at least 22-fold (1.34 log units) from the limit.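

In this assay compound 4 returns a limit of the assay, > 1000000 nM, and not a number, and it joins compound 3 in sitting at that limit: the limit of > 1000000 nM in this assay, at which 2 of the 4 values shown sit.

Within the data shown here, the change at this saturated chain carbon, two bonds along the chain from an oxygen next to a carbonyl group, appears as an at least 53-fold higher number from compound 2 to compound 4 (1.73 log units; beyond the scatter), a large step where the only earlier step, a 5.0-fold lower number from compound 1 to compound 2 (0.70 log units; beyond the scatter), was modest. Compound 4 also falls outside the span of the two ester tails with numbers, as seen in an at least 10-fold higher number from compound 1 to compound 4 (1.03 log units; beyond the scatter), so it does not behave as an intermediate case and link length alone does not order these three compounds.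

The step from compound 2 to compound 4 alters the link and the acyl group together, and no pair shown separates the share of the 1-propylbutyl group from that of the link. Also open, on these data alone, is whether a straight pentyl chain on the acyl carbonyl, or a carboxylic acid at the end of the tail, would return a number in this assay rather than a limit.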